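Replacing Phenyl on the Amide Nitrogen of Compound 3

The source may report more compounds than this note shows. Statements on the series, on what has been measured and on what is new or still open speak of the compounds shown alone.

Measured in an ADME assay on HEp-2 cells (Homo sapiens) for cytotoxicity; a lower number here means that less compound is tolerated, a higher number that more compound is tolerated:
Compound 1 `Cc1ccc(NC(=O)CNS(=O)(=O)c2cccc3cccnc23)c(C)c1`: > 50000 nM (a limit)
Compound 2 `Cc1ccc(NC(=O)C(C)NS(=O)(=O)c2cccc3cccnc23)c(C)c1`: > 50000 nM (a limit)
Compound 3 `O=C(Nc1ccccc1)[C@@H]1CCCN1S(=O)(=O)c1cccc2cccnc12`: 35600 nM

Among the compounds with values here, compound 3 holds the only actual number, 35600 nM. Compound 1 and compound 2 stand at the limit of > 50000 nM in this assay, at which 2 of the 3 values shown sit.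

Compound 4 `Cc1ccnc(C)c1NC(=O)[C@@H]1CCCN1S(=O)(=O)c1cccc2cccnc12` carries 2,4-dimethylpyridin-3-yl in place of phenyl on an amide-type nitrogen. Within the data shown here, the one measured step, a step that the two limits leave unreadable from compound 1 to compound 2, involves a different change at a different place, so it offers no size to carry over. No step beyond the scatter is therefore expected in this assay, and the estimated step is a 1.2-fold higher number from compound 3 to compound 4 (0.07 log units; within the scatter). Compound 4 is estimated at 42000 nM, with an expected range of 20000 nM to 85000 nM.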

Compound 4, half-maximal cytotoxic concentration: > 50000 nM
Compound 4: a limit, no number (the forecaster's own chance of this, stated with the estimate: 45%); middle value at least 1.1-fold (0.07 log units) away from the limit.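

In this assay, 2,4-dimethylpyridin-3-yl in place of phenyl on the amide-type nitrogen gives an at least 1.4-fold higher number from compound 3 to compound 4 (0.14 log units; that floor lies within the scatter). Compound 4 stands at a limit, so the full size of this step cannot be read, and its floor does not separate the two compounds. The earlier compounds gave no step at this place, and compound 4 now joins compound 1 and compound 2 at that limit: the limit of > 50000 nM in this assay, at which 3 of the 4 values shown sit.

The compounds shown do not separate the ring nitrogen of 2,4-dimethylpyridin-3-yl from its two methyl groups. From the compounds shown here alone, how a saturated amine such as morpholine or a carboxylic acid would read on this nitrogen also remains open.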